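The source may hold more compounds than are shown below. What is called first, only, known or untested is meant among the compounds shown, and "the series" means these compounds.

Measured compounds in a functional assay on MIA PaCa-2 cells (Homo sapiens) for antiproliferative activity, read by sulforhodamine B assay, with a stated time of 48 h; a higher number here means a weaker inhibitor, a lower number a stronger inhibitor:
- compound 1, `COc1cc(OC)c2sc(-c3ccc(N/C=C\C(=O)c4cc(OC)c(OC)c(OC)c4)cc3)nc2c1`, gives 26800 nM
- compound 2, `COc1cc(OC)c2sc(-c3ccc(N/C=C\C(=O)c4cc(OC)c(OC)c(OC)c4Br)cc3)nc2c1`, gives 19000 nM
- compound 3, `COc1ccc2nc(-c3ccc(N/C=C\C(=O)c4cc(OC)c(OC)c([N+](=O)[O-])c4)c(C)c3)sc2c1`, gives 12000 nM

Compound 1 holds the highest of the three numbers. Its nearest neighbour is compound 2: the step of a 1.4-fold lower number from compound 1 to compound 2 (0.15 log units; within the scatter) lies within the scatter, so the two cannot be ordered. Among the compounds with values here, compound 3 lies furthest from compound 1, and that gap is beyond the scatter, but compound 3 differs from compound 1 in more than one place, so no single step can be drawn from it.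

Compound 4, `COc1cc(OC)c2sc(-c3ccc(N/C=C\C(=O)c4ccc(OC)c([N+](=O)[O-])c4)cc3)nc2c1`, is not yet measured. It differs from compound 1 in one place: 4-methoxy-3-nitrophenyl in place of 3,4,5-trimethoxyphenyl on a carbonyl carbon. Within the data shown here, the only single-point step in hand, the one from compound 1 to compound 2, touches the same ring but exchanges only one hydrogen and was within the scatter. Among the measured compounds shown here, no measured step exchanges the whole ring, so the bearing of the change on this assay is not established. Compound 3 carries a nitro group on its ring and gives the lowest number of the three, which weakly hints that a nitro-bearing ring is at least tolerated. The expected step is therefore small: a 1.3-fold lower number from compound 1 to compound 4 (0.13 log units; within the scatter), likely within the scatter, with a slight lean toward a lower number. For compound 4 the estimated value in this assay is 20000 nM, within the range 8000 nM to 50000 nM.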

Compound 4, half-maximal inhibitory concentration: 2900 nM
Estimate against measurement, compound 4: 6.9-fold (0.84 log units) above; measured number below the stated range.
By their numbers in this assay, from the lowest: compound 4; then compounds 3, 2 and 1 (each within the scatter of the next, the first and the last beyond it).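

In this assay, the ring on the carbonyl carbon proves responsive when exchanged whole: 4-methoxy-3-nitrophenyl in place of 3,4,5-trimethoxyphenyl gives a 9.2-fold lower number from compound 1 to compound 4 (0.97 log units; beyond the scatter), whereas adding only a bromo group to that ring gives a 1.4-fold lower number from compound 1 to compound 2 (0.15 log units; within the scatter) and stays within the scatter. The small step therefore did not predict how this position tolerates a full change of ring, and a trimethoxyphenyl group is not required for the lower number in this assay. Both groups count the same hydrogen-bond acceptors and no donors, so those counts do not separate them, and no supporting measurement bears on the reason for the step.

The single exchange removes methoxy groups and brings in a nitro group together, so the compounds shown cannot assign the step to either part of the change. Also open, going by these compounds, is whether the nitro group itself is needed, or whether a nitrile, an amine or a carboxylic acid in its place on this ring would keep the number as low as that of compound 4.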